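Para substituent exchange on the shared core, toward compound 4

A few compounds are considered here, and "the series" means these few. Any claim that something is new, unique, unknown or untested is made for them only; others in the source may bear on it.

Going by the values given here, in an assay on mitochondria from L6 cells (Rattus norvegicus) for activation, with a stated time of 90 min (on this read-out lower numbers stand for an effect already at smaller amounts and higher numbers for an effect only at larger amounts of compound), compound 3 `CCCCCCc1ccc(Nc2nc3nonc3nc2O)cc1` gives 4700 nM, the highest of the three numbers so far. Compound 1 `Oc1nc2nonc2nc1Nc1ccc(S(F)(F)(F)(F)F)cc1` gives 3900 nM, and compound 2 `CCCCc1ccc(Nc2nc3nonc3nc2O)cc1` gives 2100 nM. The spread is narrow: a 1.2-fold higher number from compound 1 to compound 3 (0.08 log units; within the scatter), a 1.9-fold lower number from compound 1 to compound 2 (0.27 log units; within the scatter), and only a 2.2-fold higher number from compound 2 to compound 3 (0.35 log units; beyond the scatter) moved past the scatter, and then modestly.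

Compound 4 `Oc1nc2nonc2nc1Nc1ccc(OC(F)F)cc1` differs from compound 3 by difluoromethoxy in place of hexyl on an aromatic carbon.

Among the compounds with values here, two measured steps bear on this exchange of the group on the aromatic carbon: a 1.2-fold higher number from compound 1 to compound 3 (0.08 log units; within the scatter) and a 1.9-fold lower number from compound 1 to compound 2 (0.27 log units; within the scatter), both within the scatter, so replacing one such group by another has so far barely moved the read-out. Within the data shown here, the one step beyond the scatter, a 2.2-fold higher number from compound 2 to compound 3 (0.35 log units; beyond the scatter), concerns chain length and is only partly comparable. Among the measured compounds shown here, no measured compound carries difluoromethoxy, so the expectation rests on those swaps alone. For compound 4 a step of a 1.6-fold lower number from compound 3 to compound 4 (0.19 log units; within the scatter) is expected, small and toward a lower number, reflecting the trend back toward compound 2. Compound 4 is estimated at 3000 nM, in the range 1200 nM to 7500 nM.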

Compound 4, half-maximal effective concentration: 20600 nM
Estimate against measurement, compound 4: 6.9-fold (0.84 log units) below, and the stated range ends below it.
By their numbers in this assay, from the lowest: compounds 2, 1 and 3 (each within the scatter of the next, the first and the last beyond it); then compound 4.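

The group on this aromatic carbon is not interchangeable after all: in this assay, difluoromethoxy gives a 4.4-fold higher number from compound 3 to compound 4 (0.64 log units; beyond the scatter), a 9.8-fold higher number from compound 2 to compound 4 (0.99 log units; beyond the scatter) and a 5.3-fold higher number from compound 1 to compound 4 (0.72 log units; beyond the scatter), all beyond the scatter, whereas the earlier exchanges from compound 1 stayed within it. Heavy-atom count does not sort these results, since butyl in compound 2 and difluoromethoxy in compound 4 both count 4 heavy atoms yet lie at opposite ends of the series. No measurement on hand accounts for the rise.

Compound 4 is the only one shown with an oxygen on this carbon, so the oxygen and the fluorines cannot be told apart as the source of the step. A methoxy or trifluoromethoxy group at this place would separate the two.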